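The source may report more compounds than this note shows. Statements on the series, on what has been measured and on what is new or still open speak of the compounds shown alone.

Series notes. Compound 1 `O=C(N/N=C/c1ccccc1)Nc1ccc(Oc2ccnc3[nH]ccc23)cc1` and compound 2 `O=C(N/N=C/c1ccc(O)cc1)Nc1ccc(Oc2ccnc3[nH]ccc23)cc1` share one core and differ only by a hydroxy in place of hydrogen on an aromatic carbon. In a functional assay on HepG2 cells (Homo sapiens) for antiproliferative activity, read by MTT assay, with a stated time of 72 h (on this read-out higher numbers stand for weaker inhibition and lower numbers for stronger inhibition), compound 1 gives 750 nM, and in this assay compound 2 gives 32200 nM. Among the compounds with values here, the single measured step, a 43-fold higher number from compound 1 to compound 2 (1.63 log units; beyond the scatter), leaves compound 2 at the highest of the two numbers, with compound 1 as its only neighbour and far below it.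

The next compound, compound 3 `COc1ccc(/C=N/NC(=O)Nc2ccc(Oc3ccnc4[nH]ccc34)cc2)cc1`, differs from compound 2 by methyl in place of hydrogen on an oxygen on an aromatic ring. Within the data shown here, no measured step alters an oxygen on an aromatic ring, so only a 43-fold higher number from compound 1 to compound 2 (1.63 log units; beyond the scatter) bears on it, and that step shows compound 2, carrying hydroxy, standing far above compound 1, carrying hydrogen. Compound 3 carries neither, so a number between the two seems more likely than a further rise, though with little to anchor it.

For compound 3 the number in this assay is expected near 4000 nM, within 800 nM to 20000 nM. This amounts to an estimated step of an 8.1-fold lower number from compound 2 to compound 3 (0.91 log units; beyond the scatter). The measurement will decide.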

Compound 3, half-maximal inhibitory concentration: 9740 nM
Beside the measured number, compound 3's estimate is 2.4-fold (0.39 log units) below it; the range from low to high includes it.
By their numbers in this assay, from the lowest: compound 1; then compound 3; then compound 2.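

In this assay, going from 4-hydroxyphenyl to 4-methoxyphenyl gives a 3.3-fold lower number from compound 2 to compound 3 (0.52 log units; beyond the scatter) and so undoes only part of the rise seen with hydroxy when methyl replaces the hydrogen on that oxygen. Methoxy in place of hydrogen on the aromatic carbon still gives a 13-fold higher number from compound 1 to compound 3 (1.11 log units; beyond the scatter) as a large step, so both oxygen-linked groups stand above the unsubstituted compound 1, and the size of the rise changes with what sits on the oxygen. No measurement at hand gives a reason for either step.

The three compounds leave open whether the rise belongs to an oxygen at this place or to any group on this aromatic carbon, which an amine, a chlorine or a methyl directly on the ring would help to separate. They also leave open how the number responds to a longer chain on the oxygen, such as ethoxy, and whether any group here can bring the number below that of compound 1.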